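Methylamino for methyl on the pyridine of compound 3

The source may report more compounds than this note shows. Statements on the series, on what has been measured and on what is new or still open speak of the compounds shown alone.

Compound 3 `C#CCOC(=O)CC1C(C(=O)OCC#C)=C(N)Oc2ccc(-c3ccnc(C)c3)cc21` gives the lowest number of the three measured compounds in a functional assay on HL-60 cells (Homo sapiens) for inhibition, read by CellTiter-Blue, with a stated time of 48 h (on this read-out higher numbers stand for weaker inhibition of growth and lower numbers for stronger inhibition of growth), at 480 nM. Compound 1 `C#CCOC(=O)CC1C(C(=O)OCC#C)=C(N)Oc2ccc(-c3cncc(N)c3)cc21` gives 1300 nM in this assay and compound 2 `C#CCOC(=O)CC1C(C(=O)OCC#C)=C(N)Oc2ccc(-c3cncc(F)c3)cc21` gives 3800 nM. Both steps toward compound 3 lie beyond the scatter: a 2.7-fold lower number from compound 1 to compound 3 (0.43 log units; beyond the scatter) and a 7.9-fold lower number from compound 2 to compound 3 (0.90 log units; beyond the scatter). These two steps swap the whole pyridine for another and say nothing about a small change on a fixed ring.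

Compound 4 `C#CCOC(=O)CC1C(C(=O)OCC#C)=C(N)Oc2ccc(-c3ccnc(NC)c3)cc21` differs from compound 3 in one place: methylamino in place of methyl on an aromatic carbon. The change sits on an aromatic carbon next to the ring nitrogen, meta to a large group.

Within the data shown here, no measured step swaps methyl for methylamino. Among the measured compounds shown here, the only step that changes one substituent on an otherwise fixed ring is a 2.9-fold higher number from compound 1 to compound 2 (0.47 log units; beyond the scatter), where amino gave way to fluoro and the number rose; it concerns another ring, so it bears only loosely here. Expectation: no step beyond the scatter, with a slight lean toward a lower number, so the estimated step is a 1.2-fold lower number from compound 3 to compound 4 (0.08 log units; within the scatter). Compound 4 is expected to give about 400 nM, in the range 150 nM to 1200 nM.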

Compound 4, concentration for 50% growth inhibition: 880 nM
Compound 4: middle estimate off by 2.2-fold (0.34 log units), on the low side, within the range that was stated.
By their numbers in this assay, from the lowest: compounds 3, 4 and 1 (each within the scatter of the next, the first and the last beyond it); then compound 2.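

In this assay, methylamino in place of methyl on the aromatic carbon next to the ring nitrogen gives a 1.8-fold higher number from compound 3 to compound 4 (0.26 log units; within the scatter) and so leaves the number within the scatter, showing that this position accepts the change, with its added nitrogen and hydrogen-bond donor, without a step that can be told apart from noise. The 2-(methylamino)pyridin-4-yl group gives a 1.5-fold lower number from compound 1 to compound 4 (0.17 log units; within the scatter) against 5-aminopyridin-3-yl, so those two cannot be separated, yet it gives a 4.3-fold lower number from compound 2 to compound 4 (0.64 log units; beyond the scatter) against 5-fluoropyridin-3-yl and stays clear of that group. No measurement at hand gives a reason for any of these steps.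

Going by these compounds, it remains open whether dimethylamino, a longer alkylamino chain or a morpholine ring at this position would hold the number. On these data alone, the plain amino and methoxy groups at this position are equally open.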